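Chromone carboxylic acid amides: methoxypyridyl amide step

A few compounds are considered here, and "the series" means these few. Any claim that something is new, unique, unknown or untested is made for them only; others in the source may bear on it.

Measured compounds in an assay on CHO cells for agonist activity at G protein-coupled receptor GPR35 (Rattus norvegicus), read by a beta-galactosidase reporter and beta-arrestin recruitment, with a stated time of 90 min; a higher number here means that more compound is needed for the effect, a lower number that less compound is needed:
compound 1, `COc1ccc(C(=O)Nc2cc(F)cc3c(=O)cc(C(=O)O)oc23)cc1`, 1760 nM
compound 2, `O=C(Nc1cc(Br)cc2c(=O)cc(C(=O)O)oc12)c1ccccc1`, 2750 nM

Among the compounds with values here, only these two numbers exist so far, and no single-point step between them can be counted, as the two compounds differ in more than one place. On the numbers themselves, compound 1 and compound 2 sit within the scatter of each other, so neither can be called the more or the less potent; the value of compound 2 is simply one of two near-equal readings in this assay.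

Compound 3, `COc1ccc(C(=O)Nc2cc(Br)cc3c(=O)cc(C(=O)O)oc23)cn1`, keeps the shared core of compound 2 and changes only the aryl group of the amide: 6-methoxypyridin-3-yl in place of phenyl on a carbonyl carbon. Nothing measured here isolates that exchange, so the expectation rests on the near-equal values of compound 1 and compound 2 alone. With so little to go on, no step beyond the scatter is expected in this assay in either direction, and compound 3 is expected to land near compound 2, with wide uncertainty. The expected reading for compound 3 is 2200 nM (range 700 nM to 7000 nM), which means an expected step of a 1.3-fold lower number from compound 2 to compound 3 (0.10 log units; within the scatter).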

Compound 3, half-maximal effective concentration: 991 nM
Compound 3: middle estimate off by 2.2-fold (0.35 log units), on the high side; low and high end bracket the measured number.
By their numbers in this assay, from the lowest: compounds 3, 1 and 2 (each within the scatter of the next, the first and the last beyond it).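

In this assay, within the data shown here, the aryl group on a carbonyl carbon whose other neighbour is an amide-type nitrogen proves to be a place where a single exchange moves the reading: 6-methoxypyridin-3-yl in place of phenyl gives a 2.8-fold lower number from compound 2 to compound 3 (0.44 log units; beyond the scatter) as the first one-place step, and a modest one. The entering group differs from phenyl in several counted ways at once, with 8 heavy atoms against 6, a ring nitrogen, a methoxy oxygen, and 2 hydrogen-bond acceptors against 0, so this one step cannot assign the shift to any single feature. Nothing at hand gives a measured reason for the shift.

As far as these compounds go, how much of the step belongs to the ring nitrogen and how much to the methoxy group remains open, and an unsubstituted pyridin-3-yl or a dimethylamino group in place of the methoxy would help to separate the two. Also open, from the compounds shown here alone, is whether the same exchange carries over to a shared core bearing another halogen, such as chlorine.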